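Nitro for methyl on a shared core: HeLa cytotoxicity

The source may report more compounds than this note shows. Statements on the series, on what has been measured and on what is new or still open speak of the compounds shown alone.

Compound 1 `Cc1nc(-c2cccnc2)sc1-c1nnc(-c2ccc([N+](=O)[O-])cc2)o1` has a value of > 100 ug/mL in an ADME assay on HeLa cells (Homo sapiens) for cytotoxicity, read by MTT assay (on this read-out lower numbers stand for higher toxicity in this test and higher numbers for lower toxicity in this test), which is a limit of the test. Compound 2 `Cc1ccc(-c2nnc(-c3sc(-c4cccnc4)nc3C)o2)cc1` also sits at a limit, with compound 2 giving > 100 ug/mL in this assay. Compound 3 `Cc1ccccc1-c1nnc(-c2sc(-c3cccnc3)nc2C)o1` likewise reports a limit, compound 3 giving > 100 ug/mL in this assay.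

The change from compound 2 to compound 1 is nitro in place of methyl on an aromatic carbon; the step it made, a step that the two limits leave unreadable from compound 2 to compound 1, cannot be sized because both values are limits. The two cores differ by 2-methylphenyl in place of 4-methylphenyl on an aromatic carbon, and the step that the two limits leave unreadable from compound 2 to compound 3 is equally unreadable. Compound 4 `Cc1nc(-c2cccnc2)sc1-c1nnc(-c2ccccc2[N+](=O)[O-])o1` is not yet measured; its difference from compound 3 is nitro in place of methyl on an aromatic carbon. This is the same kind of change as that from compound 2 to compound 1, but not the same: there the nitro sits para to a large group, here it sits ortho to a large group.

The expected step from compound 3 to compound 4 in this assay is a step that the limit leaves unreadable from compound 3 to compound 4, resting on the limit of > 100 ug/mL in this assay, at which 3 of the 3 values shown sit, and on compound 1 at > 100 ug/mL. Compound 4 is estimated at 120 ug/mL, between 50 ug/mL and 300 ug/mL.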

Compound 4, half-maximal cytotoxic concentration: > 100 ug/mL
Compound 4: a limit, no number (the forecaster's own chance of this, stated with the estimate: 80%); the middle value is on the limit's open side.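

Among the compounds shown here, compound 3 and compound 4 both stand at a limit of the test in this assay and so no step between them can be read. The compounds shown leave open whether any of the four differs from another in toxicity, and what nitro in place of methyl does to a value that is not a limit.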